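A new group on compound 2: what to expect

The source may report more compounds than this note shows. Statements on the series, on what has been measured and on what is new or still open speak of the compounds shown alone.

In a functional assay on HL-60 cells (Homo sapiens) for antiproliferative activity, read by MTT assay, with a stated time of 48 h (on this read-out higher numbers stand for weaker inhibition and lower numbers for stronger inhibition), compound 1 `CN(C)CCn1c(N)c(-c2nc3ccccc3n2C)c2nc(C#N)c(C#N)nc21` gives > 50000 nM, which is a limit of the assay and not a number. Compound 2 `CCN(CC)CCn1c(N)c(-c2nc3ccccc3n2C)c2nc(C#N)c(C#N)nc21` gives 8800 nM, the higher of the two actual numbers. Compound 3 `CN(C)CCCn1c(N)c(-c2nc3ccccc3n2C)c2nc(C#N)c(C#N)nc21` gives 2120 nM. Compound 4 `CCN(CC)CCn1c(N)c(-c2nc3cc(Cl)ccc3[nH]2)c2nc(C#N)c(C#N)nc21` keeps the 2-(diethylamino)ethyl group of compound 2 but has 5-chloro-1H-benzimidazol-2-yl in place of 1-methyl-1H-benzimidazol-2-yl on an aromatic carbon. For the measured compounds named here, no measured step touches this group. The chain changes gave an at least 5.6-fold lower number from compound 1 to compound 2 (0.75 log units; beyond the scatter), an at least 23-fold lower number from compound 1 to compound 3 (1.37 log units; beyond the scatter) and a 4.2-fold lower number from compound 2 to compound 3 (0.62 log units; beyond the scatter), so they offer only a rough sense of how far one change can move these numbers. A modest move toward stronger inhibition is expected, a 2.9-fold lower number from compound 2 to compound 4 (0.47 log units; beyond the scatter), though its direction is uncertain. Compound 4 is estimated at 3000 nM, with an expected range of 600 nM to 15000 nM.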

Compound 4, half-maximal inhibitory concentration: > 50000 nM
Compound 4 was reported as a limit (the forecaster's own chance of this, stated with the estimate: 10%); middle value at least 16-fold (1.22 log units) from the limit.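

In this assay, replacing 1-methyl-1H-benzimidazol-2-yl with 5-chloro-1H-benzimidazol-2-yl gives an at least 5.6-fold higher number from compound 2 to compound 4 (0.75 log units; beyond the scatter), so this aromatic carbon, untouched by the chain changes, can weaken inhibition on its own. Compound 4 gives > 50000 nM, which is a limit of the assay and not a number. The full size of the step therefore stays unknown, and this limit recurs among the compounds: the limit of > 50000 nM in this assay, at which 2 of the 4 values shown sit.

The change adds a chlorine and removes the ring nitrogen's methyl at once, so the effect of each remains unseparated. Plain 1H-benzimidazol-2-yl or 5-chloro-1-methyl-1H-benzimidazol-2-yl would tell them apart.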